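A few compounds are considered here, and "the series" means these few. Any claim that something is new, unique, unknown or untested is made for them only; others in the source may bear on it.

Compound 1 `CC/C(=C(/c1ccc(/C=C/C(=O)O)cc1)c1ccc2[nH]ncc2c1)c1ccccc1`: 7.2 nM
Compound 2 `COC/C(=C(/c1ccc(/C=C/C(=O)O)cc1)c1ccc2[nH]ncc2c1)c1ccccc1`: 88 nM
Compound 3 `O=C(O)/C=C/c1ccc(/C(=C(\c2ccccc2)C2CCC2)c2ccc3[nH]ncc3c2)cc1`: 1.4 nM

These three compounds were tested in a functional assay on MCF7 cells (Homo sapiens) for cytotoxicity, read by CellTiter-Glo, with a stated time of 5 days; on this read-out lower numbers stand for stronger inhibition and higher numbers for weaker inhibition. Compound 3 gives the lowest number of the three: against compound 1 the step is a 5.1-fold lower number from compound 1 to compound 3 (0.71 log units; beyond the scatter), and against compound 2 it is a 63-fold lower number from compound 2 to compound 3 (1.80 log units; beyond the scatter). Compound 2 in turn stands apart from compound 1 by a 12-fold higher number from compound 1 to compound 2 (1.09 log units; beyond the scatter). Compound 4 `O=C(O)/C=C/c1ccc(/C(=C(\c2ccccc2)C2CCCC2)c2ccc3[nH]ncc3c2)cc1` has not yet been measured. It differs from compound 3 in one place: cyclopentyl in place of cyclobutyl on a double-bonded chain carbon bound to an aromatic carbon and a double-bonded chain carbon. Among the compounds with values here, the only measured step at this position that resembles it is the change from ethyl to cyclobutyl, which gave a 5.1-fold lower number from compound 1 to compound 3 (0.71 log units; beyond the scatter); the step that starts from methoxymethyl is less alike. Swapping a four-membered ring for a five-membered one is a smaller change than either, and nothing measured here shows its direction. The expectation for compound 4 is therefore a step of a 1.4-fold higher number from compound 3 to compound 4 (0.15 log units; within the scatter) in this assay, likely within the scatter. Compound 4 is estimated at 2 nM, with a range from 0.7 nM to 6 nM.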

Compound 4, half-maximal inhibitory concentration: 10 nM
The estimate for compound 4 lay 5.0-fold (0.70 log units) below the measured number; measured number above the stated range.
By their numbers in this assay, from the lowest: compound 3; then compounds 1 and 4 (each within the scatter of the next); then compound 2.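

In this assay, ring size matters at this position: cyclopentyl in place of cyclobutyl gives a 7.1-fold higher number from compound 3 to compound 4 (0.85 log units; beyond the scatter) and so undoes the gain seen with cyclobutyl. Cyclopentyl in place of ethyl gives only a 1.4-fold higher number from compound 1 to compound 4 (0.14 log units; within the scatter) and stays within the scatter, whereas cyclopentyl in place of methoxymethyl still gives an 8.8-fold lower number from compound 2 to compound 4 (0.94 log units; beyond the scatter) as a clear step. Nothing available here accounts for the difference between the two rings.

The compounds shown leave open how the numbers behave on either side of this pair of rings, which cyclopropyl and cyclohexyl at the same position would help to define. They also leave open whether a ring is needed at all, which an open branched group such as isopropyl would help to test.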